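The compounds below may be only part of what the source reports. "The series", "measured", "known", "first", "only" and "open" are said of these compounds alone.

The measured compounds:
Compound 1, `O=C1COc2ccc(-c3cccc(NS(=O)(=O)c4ccc(F)cc4)c3)cc2N1c1ccccc1`, in a functional assay on A-375 cells (Homo sapiens) for antiproliferative activity, read by MTT assay, with a stated time of 72 h (on this read-out lower numbers stand for stronger inhibition and higher numbers for weaker inhibition), gives > 40000 nM, which is a limit of the assay rather than a number.
Compound 2, `Cc1ccc(N2C(=O)COc3ccc(-c4cccc(NS(=O)(=O)c5ccc(F)cc5)c4)cc32)cc1`, in this assay gives 36200 nM.

Among the compounds with values here, compound 2 therefore carries the only numerical value on this read-out; the one other result is a limit, (the limit of > 40000 nM in this assay, at which 1 of the 2 values shown sits). Within the data shown here, the single measured step, an at least 1.1-fold lower number from compound 1 to compound 2 (0.04 log units; that floor lies within the scatter), concerns the methyl in place of hydrogen on an aromatic carbon, and its floor lies within the scatter.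

Compound 3, `O=C1COc2ccc(-c3cccc(NS(=O)(=O)c4ccc(F)cc4)c3)cc2N1C1CCCCC1`, is not yet measured. Relative to compound 2 it differs by cyclohexyl in place of 4-methylphenyl on an amide-type nitrogen in a ring. Among the measured compounds shown here, no measured step concerns an exchange of this kind on the amide-type nitrogen in a ring; the only measured step touches an aromatic carbon and did not exceed the scatter. Nothing in the two values points toward a change in either direction. Compound 3 is therefore expected to give a number close to that of compound 2. The step of a 1.2-fold lower number from compound 2 to compound 3 (0.08 log units; within the scatter) is estimated to stay within the scatter. Compound 3 is estimated at 30000 nM in this assay, with a range from 10000 nM to 100000 nM.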

Compound 3, half-maximal inhibitory concentration: 23800 nM
Beside the measured number, compound 3's estimate is 1.3-fold (0.10 log units) above it, within the range that was stated.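

Within the data shown here, this is the first measured exchange on the amide-type nitrogen in a ring, and it puts a non-aromatic ring of carbon only, cyclohexyl, where 4-methylphenyl stood: in this assay it gives a 1.5-fold lower number from compound 2 to compound 3 (0.18 log units; within the scatter), so on this read-out the exchange does not separate compound 3 from compound 2. The same position can also be read against the unsubstituted phenyl group, with an at least 1.6-fold lower number from compound 1 to compound 3 (0.22 log units; that floor lies within the scatter), which again shows no change beyond the scatter. That step can only be read as a floor, since the result for compound 1 is a limit and not a number: the limit of > 40000 nM in this assay, at which 1 of the 3 values shown sits.

On these data alone, what remains open is whether any group on this nitrogen can move the number beyond the scatter, for instance a longer chain ending in an amine, or a carboxylic acid, neither of which resembles the carbon rings compared here. The compounds shown also leave open whether changes elsewhere on the shared core would have a larger effect in this assay, as they vary in this one position and on the aromatic carbon of its substituent only.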